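The source may report more compounds than this note shows. Statements on the series, on what has been measured and on what is new or still open speak of the compounds shown alone.

Values so far in a functional assay on CWR22R cells (Homo sapiens) for antiproliferative activity, read by propidium iodide staining, with a stated time of 96 h; a lower number here means a stronger inhibitor, a higher number a weaker inhibitor
compound 1 (`CC(O)(COc1ccc(OC(F)(F)F)cc1)C(=O)Nc1ccc(S(F)(F)(F)(F)F)cc1`) at 27900 nM
compound 2 (`CC(O)(CS(=O)(=O)c1ccc(S(F)(F)(F)(F)F)cc1)C(=O)Nc1ccc(S(F)(F)(F)(F)F)cc1`) at 17300 nM
compound 3 (`CC(O)(CS(=O)(=O)c1ccc(F)cc1)C(=O)Nc1ccc(S(F)(F)(F)(F)F)cc1`) at 20600 nM

Compound 3 at 20600 nM lies within the scatter of both other compounds, so these numbers do not separate it from them. Compound 4 (`CC(O)(CS(=O)(=O)c1ccc(C(F)(F)F)cc1)C(=O)Nc1ccc(S(F)(F)(F)(F)F)cc1`) differs from compound 3 by a single change (trifluoromethyl in place of fluoro on an aromatic carbon), trifluoromethyl in place of fluoro on an aromatic carbon, para to a large group. Going by the values given here, the only measured step at that place (a 1.2-fold higher number from compound 2 to compound 3 (0.08 log units; within the scatter)) put fluorine in for a larger group and stayed within the scatter. With that one step as a guide, no shift beyond the scatter is expected in this assay here. The estimated step (a 1.1-fold lower number from compound 3 to compound 4 (0.04 log units; within the scatter)) is therefore small. For compound 4 the estimate is 19000 nM, with an expected range of 10000 nM to 35000 nM around it.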

Compound 4, half-maximal inhibitory concentration: 28900 nM
Compound 4: the middle estimate sits 1.5-fold (0.18 log units) below what was measured; measured number inside the range.
By their numbers in this assay, from the lowest: compounds 2, 3, 1 and 4 (each within the scatter of the next).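

In this assay, trifluoromethyl in place of fluoro on this aromatic carbon gives a 1.4-fold higher number from compound 3 to compound 4 (0.15 log units; within the scatter), and trifluoromethyl in place of the sulfur group carrying five fluorines gives a 1.7-fold higher number from compound 2 to compound 4 (0.22 log units; within the scatter). Going by these compounds alone, the single earlier step compared only two groups at this place; now three groups lie within the scatter of one another, so these numbers do not separate them. No measurement available here speaks to why this is so. The compounds shown leave open whether an amine, a carboxylic acid or a longer carbon chain at this place would shift the number beyond the scatter.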